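Amide nitrogen variation: from butyl to pyridin-3-yl

The compounds below may be only part of what the source reports. "The series", "measured", "known", "first", "only" and "open" are said of these compounds alone.

compound 1 `CCCCNC(=O)c1c(O)c2cccnc2n(-c2ccccc2)c1=O`: 12.8%
compound 2 `O=C(NCc1ccccc1)c1c(O)c2cccnc2n(-c2ccccc2)c1=O`: 1.6%
compound 3 `O=C(Nc1ccccc1)c1c(O)c2cccnc2n(-c2ccccc2)c1=O`: 4.6%

All three compounds share one core and differ only in the group on the amide-type nitrogen. In a functional assay on the whole organism for inhibition, with Rattus norvegicus as the target, read by paw edema, at a dose of 100 mg/kg by the oral route (a lower number here means less inhibition, a higher number more inhibition at the dose given (going by the name of the read-out)), compound 1 gives the highest of the three numbers, though its step to compound 3 is within the scatter: a number 8.2 percentage points lower from compound 1 to compound 3 (within the scatter). The step of a number 11.2 percentage points lower from compound 1 to compound 2 (beyond the scatter) is beyond the scatter, and a number 3 percentage points higher from compound 2 to compound 3 (within the scatter) is within it.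

Compound 4 `O=C(Nc1cccnc1)c1c(O)c2cccnc2n(-c2ccccc2)c1=O` is not yet measured. It differs from compound 1 by pyridin-3-yl in place of butyl on an amide-type nitrogen. The measured steps that bear on it are those setting an aromatic ring on the amide-type nitrogen in place of a chain: a number 8.2 percentage points lower from compound 1 to compound 3 (within the scatter) and, with the ring one carbon further out, a number 11.2 percentage points lower from compound 1 to compound 2 (beyond the scatter). Both lower the number. A step of the same kind, a number 7.8 percentage points lower from compound 1 to compound 4 (within the scatter), is expected, small and downward, likely at the edge of the scatter. Compound 4 is therefore estimated at 5%, with an expected range from -3% to 13%.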

Compound 4, a percentage reported as inhibition, in the whole organism at one dose (the size of the read-out at that dose, not a potency): 30.3%
The estimate for compound 4 lay 25.3 percentage points below the measured number; measured number outside the range, above it.
By their numbers in this assay, from the lowest: compounds 2, 3 and 1 (each within the scatter of the next, the first and the last beyond it); then compound 4.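

In this assay, an aromatic ring on the amide-type nitrogen does not by itself lower the number: the pyridin-3-yl group goes against the downward steps seen with phenyl and benzyl, giving a number 17.5 percentage points higher from compound 1 to compound 4 (beyond the scatter). The outcome at this position depends on the kind of ring, since pyridin-3-yl in place of phenyl gives a number 25.7 percentage points higher from compound 3 to compound 4 (beyond the scatter), and pyridin-3-yl in place of benzyl gives a number 28.7 percentage points higher from compound 2 to compound 4 (beyond the scatter). Nothing available explains these rises.

Open, as far as these compounds go, is whether the higher number is particular to pyridin-3-yl or is shared by pyridin-2-yl and pyridin-4-yl. Also open, from the compounds shown here alone, is whether it survives when a carbon is set between the amide-type nitrogen and the ring, as in pyridin-3-ylmethyl.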